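Ethyl on the ring amine: compound 2 to compound 3

The compounds below may be only part of what the source reports. "The series", "measured", "known", "first", "only" and "open" are said of these compounds alone.

Of the compounds shown here, two have been measured in a functional assay on the whole organism with Rattus norvegicus as the target, at a dose of 40 mg/kg by the intraperitoneal route; a lower number here means less inhibition, a higher number more inhibition at the dose given (going by the name of the read-out). Compound 1 `Cc1nc2c(OCc3cccs3)cccn2c1N` gives 70% in this assay. Compound 2 `Cc1nc2c(CCc3ccccc3)cccn2c1N` gives 47% in this assay, the lower of the two numbers; compound 1 sits higher, and the gap between them lies beyond the scatter. The two differ in more than one place, so nothing is drawn from that gap about any single change.

Compound 3 `CCNc1c(C)nc2c(CCc3ccccc3)cccn12` is not yet measured in this assay. Against compound 2 it carries the change (ethyl in place of hydrogen on a nitrogen on an aromatic ring), that is ethyl in place of hydrogen on a nitrogen on an aromatic ring. Among the measured compounds shown here, no measured pair shows what this change does; with nothing to rest on, the expected step from compound 2 to compound 3, a number 2 percentage points lower from compound 2 to compound 3 (within the scatter), is none beyond the scatter. Compound 3 is therefore estimated at 45% in this assay, within the range 22% to 68%.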

Compound 3, a percentage reported as inhibition, in the whole organism at one dose (the size of the read-out at that dose, not a potency): 78%
Beside the measured number, compound 3's estimate is 33 percentage points below it; measured number outside the range, above it.
By their numbers in this assay, from the lowest: compound 2; then compounds 1 and 3 (each within the scatter of the next).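

In this assay, among the compounds shown here, the nitrogen on the aromatic ring accepts a substituent, and the first single-place pair of the series gives a number 31 percentage points higher from compound 2 to compound 3 (beyond the scatter) for the change from amino to ethylamino. The hydrogen on that nitrogen can therefore be replaced by ethyl without loss at this dose, and this position now appears as one where a small change moves the read-out well beyond the scatter. For the compounds shown here, nothing measured so far accounts for the size of this step.

On these data alone, whether the gain is particular to ethyl stays open: methyl, a longer chain such as propyl, or an acetyl group on the same nitrogen would show whether the step grows, holds or reverses. Also open, as far as these compounds go, is whether amino to ethylamino gives a similar step when the side chain of compound 1 is present.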